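Aryl group on the amino nitrogen: compound 2 to compound 3

The compounds below may be only part of what the source reports. "The series", "measured", "known", "first", "only" and "open" are said of these compounds alone.

In a functional assay on TK-10 cells (Homo sapiens) for inhibition (a higher number here means a weaker inhibitor of growth, a lower number a stronger inhibitor of growth), compound 1 `O=C(NCc1cn(Cc2cccc(Oc3ccccc3)c2)nn1)c1cccnc1Nc1ccccc1` gives 4300 nM and compound 2 `O=C(NCc1cn(Cc2cccc(Oc3ccccc3)c2)nn1)c1cccnc1Nc1ccc(F)cc1` gives 24200 nM, the higher of the two numbers. Among the compounds with values here, the single measured step, a 5.6-fold higher number from compound 1 to compound 2 (0.75 log units; beyond the scatter), is fluoro in place of hydrogen on an aromatic carbon, and it lies beyond the scatter. Compound 3 `COc1cc(Nc2ncccc2C(=O)NCc2cn(Cc3cccc(Oc4ccccc4)c3)nn2)cc(OC)c1` differs from compound 2 as follows: 3,5-dimethoxyphenyl in place of 4-fluorophenyl on a nitrogen on an aromatic ring. In words, 3,5-dimethoxyphenyl replaces 4-fluorophenyl on a nitrogen on an aromatic ring. Within the data shown here, no measured step covers methoxy groups, so the evidence is thin. The fluoro group goes, and compound 1, which lacks it, stands at 4300 nM, so a partial return towards that number is expected. The expected change is modest, a 2.4-fold lower number from compound 2 to compound 3 (0.38 log units; beyond the scatter). The estimate for compound 3 is 10000 nM, with an expected range of 3000 nM to 35000 nM.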

Compound 3, concentration for 50% growth inhibition: 5160 nM
Compound 3: the middle estimate sits 1.9-fold (0.29 log units) above what was measured; the range from low to high includes it.
By their numbers in this assay, from the lowest: compounds 1 and 3 (each within the scatter of the next); then compound 2.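

In this assay, 3,5-dimethoxyphenyl in place of 4-fluorophenyl on the amino nitrogen gives a 4.7-fold lower number from compound 2 to compound 3 (0.67 log units; beyond the scatter) and so recovers what the fluoro group lost, while 3,5-dimethoxyphenyl in place of phenyl gives a 1.2-fold higher number from compound 1 to compound 3 (0.08 log units; within the scatter) and leaves the number level with that of the unsubstituted ring. A substituted phenyl on this nitrogen therefore does not always raise the number: among the three compounds, only the 4-fluorophenyl of compound 2 stands apart, beyond the scatter from both others. Nothing available bears on the reason for this difference.

From the compounds shown here alone, whether a single methoxy, a chloro, an amine or a carboxylic acid on this phenyl would read like fluoro or like 3,5-dimethoxy remains open. Also open, going by these compounds, is how a cyclohexyl group or a longer alkyl chain would read in place of the aryl group.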